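The source may report more compounds than this note shows. Statements on the series, on what has been measured and on what is new or still open speak of the compounds shown alone.

Compounds measured so far:
compound 1, `COc1ccc(/C=C/C(=O)OC[C@@H](OCc2ccccc2)[C@H]2OC(=O)C=C[C@H]2OCc2ccccc2)cc1`: 3260 nM
compound 2, `CC(=O)OC[C@@H](OCc1ccccc1)[C@H]1OC(=O)C=C[C@H]1OCc1ccccc1`: 6420 nM

In a functional assay on MDA-MB-231 cells (Homo sapiens) for antiproliferative activity, read by MTT assay, with a stated time of 6 days (on this read-out lower numbers stand for stronger inhibition and higher numbers for weaker inhibition), compound 2 gives the higher of the two numbers, and compound 1 the lower. Among the measured compounds shown here, the one measured step, a 2.0-fold higher number from compound 1 to compound 2 (0.29 log units; within the scatter), swaps the group on the carbonyl carbon of the ester, and the change it brings stays within the scatter. Compound 3, `O=C1C=C[C@@H](OCc2ccccc2)[C@@H]([C@@H](CO)OCc2ccccc2)O1`, is not yet measured. It differs from compound 2 in one place: hydrogen in place of acetyl on an oxygen on a saturated carbon. This removes the ester entirely, leaving a hydroxymethyl group at that position. The earlier step bears on it as a change at the same arm of the molecule, and it was small. So the step from compound 2 to compound 3 is also expected to be small, perhaps a slightly higher number, though not beyond the scatter. For compound 3 the expected value in this assay is 8000 nM, with a range of 3000 nM to 25000 nM, which corresponds to an expected step of a 1.2-fold higher number from compound 2 to compound 3 (0.10 log units; within the scatter).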

Compound 3, half-maximal inhibitory concentration: 4790 nM
Estimate against measurement, compound 3: 1.7-fold (0.22 log units) above; the measured number falls inside the stated range.
By their numbers in this assay, from the lowest: compounds 1, 3 and 2 (each within the scatter of the next).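

In this assay, taking the acetyl group off this oxygen gives a 1.3-fold lower number from compound 2 to compound 3 (0.13 log units; within the scatter) and taking off the larger (2-(4-methoxyphenyl)ethenyl)carbonyl group gives a 1.5-fold higher number from compound 1 to compound 3 (0.17 log units; within the scatter) as well. The earlier pair showed only that one ester could stand in for another, whereas these steps show that the ester can go altogether, leaving a free hydroxy, with all three compounds staying within the scatter of their neighbours. Nothing measured here gives a reason for this flat result.

On these data alone, an amine or a carboxylic acid in place of the hydroxy, or a longer chain on this oxygen, might still shift the number, so the limits of what this position accepts stay open. As far as these compounds go, how much the rest of the shared core contributes also remains open.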